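The compounds below may be only part of what the source reports. "The series", "measured", "known", "first", "only" and "open" are said of these compounds alone.

Measured set in a functional assay on PC-3 cells (Homo sapiens) for cytotoxicity, read by sulforhodamine B assay, with a stated time of 48 h; a higher number here means a weaker inhibitor, a lower number a stronger inhibitor:
compound 1 `CC1=C(/C=C/C(=O)/C=C/c2ccccc2)C(C)(C)CCC1` gives 12400 nM
compound 2 `CC1=C(/C=C/C(=O)/C=C/c2ccccc2Cl)C(C)(C)CCC1` gives 11300 nM
compound 3 `CC1=C(/C=C/C(=O)/C=C/c2ccccc2F)C(C)(C)CCC1` gives 3400 nM

Compound 3 holds the lowest number of the three; the steps to it were a 3.6-fold lower number from compound 1 to compound 3 (0.56 log units; beyond the scatter) and a 3.3-fold lower number from compound 2 to compound 3 (0.52 log units; beyond the scatter), both modest, while a 1.1-fold lower number from compound 1 to compound 2 (0.04 log units; within the scatter). Compound 4 `CC1=C(/C=C/C(=O)/C=C/c2cccnc2)C(C)(C)CCC1` differs from compound 3 in one place: pyridin-3-yl in place of 2-fluorophenyl on a double-bonded chain carbon bound to a double-bonded chain carbon. Within the data shown here, no measured step swaps one ring for another; the steps seen concern only a substituent on an aromatic carbon, and the fluoro that set compound 3 apart is gone here. The expected step in this assay is therefore a 2.9-fold higher number from compound 3 to compound 4 (0.47 log units; beyond the scatter), a higher number back toward the level of compound 1, with wide uncertainty. Compound 4 is expected at 10000 nM, range 3000 nM to 30000 nM.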

Compound 4, half-maximal inhibitory concentration: 10200 nM
Estimate against measurement, compound 4: 1.0-fold (0.01 log units) below, and the stated range covers the measured number.
By their numbers in this assay, from the lowest: compound 3; then compounds 4, 2 and 1 (each within the scatter of the next).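

In this assay, replacing the whole ring at this place gives a 3.0-fold higher number from compound 3 to compound 4 (0.48 log units; beyond the scatter), while the other two comparisons give a 1.1-fold lower number from compound 2 to compound 4 (0.04 log units; within the scatter) and a 1.2-fold lower number from compound 1 to compound 4 (0.08 log units; within the scatter). A ring hetero atom in pyridin-3-yl therefore leaves compound 4 level with the phenyl and 2-chlorophenyl compounds, and among the four compounds only the 2-fluorophenyl of compound 3 stands apart. No available evidence bears on this result. Still open, on these data alone, is whether a fluoro on the pyridin-3-yl ring would restore the number of compound 3, and whether a methoxy or an amine on the aromatic ring would shift it.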